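The source may hold more compounds than are shown below. What is called first, only, known or untested is meant among the compounds shown, and "the series" means these compounds.

Compound 1 `CC(C)[C@H](NC(=O)CN(c1nc(Cl)nc2[nH]cnc12)C1CC1)C(=O)OCc1ccccc1` gives 51.3% in a functional assay on the whole organism (Tail, strain ICR) with Mus musculus as the target, in the tail flick test, with a stated time of 90 min, at a dose of 25 umol/kg by the oral route; on this read-out higher numbers stand for a stronger effect at the one dose given and lower numbers for a weaker effect
Compound 2 `O=C(CN(c1nc(Cl)nc2[nH]cnc12)C1CC1)N[C@@H](CCC(=O)OCc1ccccc1)C(=O)OCc1ccccc1` gives 50% in this assay
Compound 3 `NC(=O)C[C@H](NC(=O)CN(c1nc(Cl)nc2[nH]cnc12)C1CC1)C(=O)O` gives 20.1% in this assay

Compound 3 stands lowest of the three measured numbers in this assay: compound 2 lies a number beyond the scatter above it, and compound 1 lies further still, also beyond the scatter. Compound 4 `NC(=O)C[C@H](NC(=O)CN(c1nc(Cl)nc2[nH]cnc12)C1CC1)C(=O)OCc1ccccc1` has not yet been measured in this assay. It differs from compound 3 by benzyl in place of hydrogen on an oxygen next to a carbonyl group, so that the carboxy of compound 3 becomes a benzyloxycarbonyl in compound 4.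

Among the measured compounds shown here, the single measured step, a number 1.3 percentage points lower from compound 1 to compound 2 (within the scatter), alters the saturated chain carbon and not the oxygen next to a carbonyl group, so it does not bear on this change. What does bear on it is the standing of the numbers: compound 1 and compound 2, both carrying a benzyloxycarbonyl, give the two higher values, while compound 3, with a carboxy, gives the lowest, beyond the scatter below either. For the measured compounds named here, on that basis an upward step, a number 21.9 percentage points higher from compound 3 to compound 4 (beyond the scatter), is expected in this assay, with wide uncertainty because only three compounds are known. Compound 4 is therefore estimated at 42% in this assay, expected to fall between 22% and 60%.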

Compound 4, a percentage reported as activity, at one dose (the size of the read-out at that dose, not a potency): 32.3%
Beside the measured number, compound 4's estimate is 9.7 percentage points above it; the range from low to high includes it.
By their numbers in this assay, from the lowest: compound 3; then compound 4; then compounds 2 and 1 (each within the scatter of the next).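

In this assay, the change from carboxy to benzyloxycarbonyl can now be read directly, as a pair differing only by benzyl in place of hydrogen on an oxygen next to a carbonyl group: a number 12.2 percentage points higher from compound 3 to compound 4 (beyond the scatter). The benzyloxycarbonyl does not by itself bring a compound up to the two higher values, since the side chain also matters, with a number 17.7 percentage points lower from compound 2 to compound 4 (beyond the scatter) for carbamoyl in place of (benzyloxycarbonyl)methyl and a number 19 percentage points lower from compound 1 to compound 4 (beyond the scatter) for carbamoylmethyl in place of isopropyl. No measurement is available that would explain these steps in this whole-animal test.

The compounds shown leave open whether this gain belongs to benzyl specifically or would also appear with a methyl or an ethyl on the same oxygen. They also leave open whether a carboxy in place of the benzyloxycarbonyl would give a step of similar size with the isopropyl of compound 1, or whether a longer chain carrying a carbamoyl, or an amine on that chain, would alter the value of compound 4.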